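Replacing a Bromohydroxyphenyl with Fluorophenyl: Expected Growth Inhibition

The source may hold more compounds than are shown below. What is called first, only, known or untested is meant among the compounds shown, and "the series" means these compounds.

Measured compounds:
Compound 1 `O=C(O)c1ccc(C(=O)/C(=C\c2ccc(Br)cc2)SCc2ccc(Br)cc2)cc1` gives 1000 nM in a functional assay on DU-145 cells (Homo sapiens) for inhibition, read by trypan blue exclusion, with a stated time of 96 h; a higher number here means a weaker inhibitor of growth, a lower number a stronger inhibitor of growth.
Compound 2 `O=C(O)c1ccc(C(=O)/C(=C\c2ccc(O)c(Br)c2)SCc2ccc(Br)cc2)cc1` gives 25000 nM.
Compound 3 `O=C(/C(=C\c1ccc(Br)cc1)SCc1ccc(F)cc1)c1ccc(Br)cc1` gives 25000 nM.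

Compound 2 stands level with compound 3 at the digits shown, the two together carrying the highest numbers of the three, while compound 1 lies far off: a 25-fold higher number from compound 1 to compound 2 (1.40 log units; beyond the scatter).

Compound 4 `O=C(O)c1ccc(C(=O)/C(=C\c2ccccc2F)SCc2ccc(Br)cc2)cc1` differs from compound 2 in one place: 2-fluorophenyl in place of 3-bromo-4-hydroxyphenyl on a double-bonded chain carbon bound to a double-bonded chain carbon. Among the measured compounds shown here, the only step that bears on this is a 25-fold higher number from compound 1 to compound 2 (1.40 log units; beyond the scatter), a large rise when the 3-bromo-4-hydroxyphenyl arrived. For the measured compounds named here, compound 4 removes that group again in favour of a halogen-bearing phenyl, so a sizeable fall in this assay is expected, though no measured compound carries a 2-fluorophenyl, which keeps the range wide. Compound 4 is therefore estimated at 2500 nM (range 600 nM to 15000 nM), an expected step of a 10-fold lower number from compound 2 to compound 4 (1.00 log units; beyond the scatter).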

Compound 4, concentration for 50% growth inhibition: 10000 nM
Beside the measured number, compound 4's estimate is 4.0-fold (0.60 log units) below it; the measured number falls inside the stated range.
By their numbers in this assay, from the lowest: compound 1; then compound 4; then compounds 2 and 3 (each within the scatter of the next).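

In this assay, 2-fluorophenyl at this position gives only a partial recovery, with a 2.5-fold lower number from compound 2 to compound 4 (0.40 log units; beyond the scatter), while the 4-bromophenyl of compound 1 stays clearly ahead, with a 10-fold higher number from compound 1 to compound 4 (1.00 log units; beyond the scatter). Losing the 3-bromo-4-hydroxyphenyl is therefore not enough to restore the number of compound 1, and the three groups here give three separate levels. No available evidence accounts for this order. The compounds shown leave open whether the halogen or its place on the ring sets the remaining gap. A 4-fluorophenyl, a 2-bromophenyl or an unsubstituted phenyl on this carbon would separate these.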